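Chloro to Hydrogen in a Series Without Cytotoxic Signal

The source may report more compounds than this note shows. Statements on the series, on what has been measured and on what is new or still open speak of the compounds shown alone.

Of the compounds shown here, three have so far been measured in an ADME assay on HCT-116 cells (Homo sapiens) for cytotoxicity, read by MTT assay, with a stated time of 48 h, tested at 0.2 uM; on this read-out higher numbers stand for a stronger effect at the one concentration tested and lower numbers for a weaker effect. Compound 1, `O=C1C(=O)N(CC(CO)NCCCCNc2ccnc3cc(Cl)ccc23)c2ccccc21`, gives 0%. Compound 2, `O=C1C(=O)N(CC(CO)NCCNc2ccnc3cc(Cl)ccc23)c2ccc(Cl)cc21`, gives 0%. Compound 3, `O=C1C(=O)N(CC(CO)NCCCCNc2ccnc3cc(Cl)ccc23)c2ccc(F)cc21`, gives -1%. On these numbers compound 2 stands level with compound 1 at the digits shown, the two together forming the highest of the three readings; compound 3 is furthest from it, yet none of these gaps lies beyond the scatter. Compound 4, `O=C1C(=O)N(CC(CO)NCCNc2ccnc3cc(Cl)ccc23)c2ccccc21`, has not been measured; it differs from compound 2 in one place, (hydrogen in place of chloro on an aromatic carbon). Among the measured compounds shown here, the one measured single step at an aromatic carbon is a number 1 percentage points lower from compound 1 to compound 3 (within the scatter), which left the reading unchanged. Compound 1 and compound 2, which differ in more than one place, also show the same value. Nothing here points to movement, and compound 4 is therefore expected to give 0%, between -8% and 8%. The expected step is no change at the digits printed from compound 2 to compound 4 (within the scatter), none beyond the scatter.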

Compound 4, a percentage reported as inhibition, at one concentration (the size of the read-out at that concentration, not a potency): 0%
Compound 4: the middle estimate sits on the measured number at the digits printed, and the stated range covers the measured number.
By their numbers in this assay, from the lowest: compounds 3, 1, 2 and 4 (each within the scatter of the next).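

In this assay, removing the chloro from this aromatic carbon gives no change at the digits printed from compound 2 to compound 4 (within the scatter), so a step that takes a halogen away now stands beside one that puts a halogen on. With a number 1 percentage points lower from compound 1 to compound 3 (within the scatter) on the compounds with the other chain, the same carbon has now been changed in both chain settings, and neither single step lies beyond the scatter. No measured property bears on why the reading stays where it does.

All four compounds read close to nothing at the one concentration tested, so these steps cannot show whether this position could affect the reading in a compound with a clear signal. On these data alone, it also remains open whether a larger or charged group here, such as a methoxy group, an amine or a carboxylic acid, would give a reading beyond the scatter.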